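The compounds below may be only part of what the source reports. "The series", "measured", "known", "first", "only" and "open" are said of these compounds alone.

Compound 1 `C[C@@H](O)[C@H]1C(=O)N2C(C(=O)OCOC(=O)C3CCCCC3)=C(S[C@@H]3CN[C@H](C(=O)Nc4cccc(C(=O)O)c4)C3)[C@H](C)[C@H]12` was tested in a physicochemical assay for metabolic stability, read by LC-MS, in phosphate buffer, with a stated time of 3 h, at pH 7.4, tested at 50 uM; on this read-out higher numbers stand for a more stable compound and lower numbers for a less stable compound. Here compound 1 gives > 95%, which is a limit of the assay rather than a number. Compound 2 `CCOC(=O)c1cccc(NC(=O)[C@@H]2C[C@H](SC3=C(C(=O)O)N4C(=O)[C@H]([C@@H](C)O)[C@H]4[C@H]3C)CN2)c1` keeps the same core with an ethyl ester at the outer end, and in this assay compound 2 gives > 95%, again a limit. Compound 3 `C[C@@H](O)[C@H]1C(=O)N2C(C(=O)OCOC(=O)C3CCCCC3)=C(S[C@@H]3CN[C@H](C(=O)Nc4cccc(C(=O)OCOC(=O)C5CCCCC5)c4)C3)[C@H](C)[C@H]12` carries the ((cyclohexylcarbonyl)oxy)methyl group at both ends, and compound 3 gives > 95%, also a limit. For the measured compounds named here, the only measured step, a step that the two limits leave unreadable from compound 1 to compound 3, therefore tells nothing about size, because of the limit of > 95% in this assay, at which 3 of the 3 values shown sit.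

Compound 4 `CC(C)OC(=O)C1=C(S[C@@H]2CN[C@H](C(=O)Nc3cccc(C(=O)O)c3)C2)[C@H](C)[C@@H]2[C@@H]([C@@H](C)O)C(=O)N12` differs from compound 1 in one place: isopropyl in place of ((cyclohexylcarbonyl)oxy)methyl on an oxygen next to a carbonyl group. Going by the values given here, no measured pair isolates this exchange, so the expectation rests on the fact that every value shown so far sits at the same limit. Compound 4 is therefore expected to remain at 96%, with a likely range from 85% to 100%. The estimated step that the limit leaves unreadable from compound 1 to compound 4 is expected to stay within the scatter.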

Compound 4, percent of the compound remaining: > 95%
Compound 4 was reported as a limit; the forecaster's own chance of this, stated with the estimate: 75%; the middle value is on the limit's open side.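

In this assay, for the compounds shown here, compound 1 and compound 4 are both reported as limits, so no step between them can be read: the limit of > 95% in this assay, at which 4 of the 4 values shown sit. Whether the group on the oxygen next to a carbonyl group changes the stability at all stays open across the compounds shown.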